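Cyano for Bromo: Expected Cytotoxicity of Compound 4

A few compounds are considered here, and "the series" means these few. Any claim that something is new, unique, unknown or untested is made for them only; others in the source may bear on it.

Compound 1 `O=c1c(OCc2cccc(Br)c2)c(-c2ccccc2)oc2cc(O)cc(O)c12` and compound 2 `N#Cc1cccc(COc2c(-c3ccccc3)oc3cc(O)cc(O)c3c2=O)c1` share one core and differ by cyano in place of bromo on an aromatic carbon. In an ADME assay on Huh-5-2 cells (Homo sapiens) for cytotoxicity, read by WST assay, with a stated time of 3 days (on this read-out higher numbers stand for lower toxicity in this test and lower numbers for higher toxicity in this test), compound 1 gives 15000 nM, while compound 2 gives 21000 nM. That step is a 1.4-fold higher number from compound 1 to compound 2 (0.15 log units; within the scatter). Compound 3 `O=c1c(OCc2ccc(Br)cc2)c(-c2ccccc2)oc2cc(O)cc(O)c12` differs from compound 1 by 4-bromophenyl in place of 3-bromophenyl on a saturated chain carbon bound to an oxygen on an aromatic ring; in this assay compound 3 gives 2000 nM. The steps are a 7.5-fold lower number from compound 1 to compound 3 (0.88 log units; beyond the scatter) and an 11-fold lower number from compound 2 to compound 3 (1.02 log units; beyond the scatter). Compound 4 `N#Cc1ccc(COc2c(-c3ccccc3)oc3cc(O)cc(O)c3c2=O)cc1` is not yet measured and differs from compound 3 by cyano in place of bromo on an aromatic carbon. This is the same kind of change as that between compound 1 and compound 2, but here the place is para to a large group, whereas there it is meta to a large group. Because the earlier step was a 1.4-fold higher number from compound 1 to compound 2 (0.15 log units; within the scatter), the step from compound 3 to compound 4 is expected to be a 1.4-fold higher number from compound 3 to compound 4 (0.15 log units; within the scatter). Compound 4 is accordingly estimated at 2800 nM, with a range from 1000 nM to 8000 nM.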

Compound 4, half-maximal cytotoxic concentration: 48000 nM
Compound 4: the middle estimate sits 17-fold (1.23 log units) below what was measured, and the stated range ends below it.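

In this assay, cyano in place of bromo gave a 24-fold higher number from compound 3 to compound 4 (1.38 log units; beyond the scatter), so the size of this step did not carry over unchanged from the core of compound 1 to the core of compound 3: the same change on two cores in this assay, a 1.4-fold higher number (0.15 log units; within the scatter) from compound 1 to compound 2 and a 24-fold higher number (1.38 log units; beyond the scatter) from compound 3 to compound 4, 17-fold (1.23 log units) apart, beyond the scatter of two such steps Among the other pairs, 4-cyanophenyl in place of 3-cyanophenyl gave a 2.3-fold higher number from compound 2 to compound 4 (0.36 log units; beyond the scatter), and 4-cyanophenyl in place of 3-bromophenyl gave a 3.2-fold higher number from compound 1 to compound 4 (0.51 log units; beyond the scatter). These four compounds show that the step differed with the place of the change, but they do not show why, and two pairs give no rule for any other core.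

The compounds shown leave open how an amine or a carboxylic acid in the place of the cyano group would read in this assay. They also leave open what a longer chain in place of the 4-cyanobenzyl group would give.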